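The source may hold more compounds than are shown below. What is called first, only, known or untested is meant among the compounds shown, and "the series" means these compounds.

Measured so far in an assay on MDA-MB-231 cells for binding affinity to C-X-C chemokine receptor type 4 (Homo sapiens), read by immunofluorescence and microscopy, with stated times of 10 min and 30 min; on this read-out higher numbers stand for an effect only at larger amounts of compound and lower numbers for an effect already at smaller amounts:
Compound 1, `Cc1ccc(S(=O)(=O)NCc2ccc(CNC(=O)c3c(Cl)cc(Cl)cc3Cl)cc2)cc1`, gives 10 nM.
Compound 2, `Cc1ccc(S(=O)(=O)NCc2ccc(CNC(=O)c3ccccc3)cc2)cc1`, is reported only as a limit of this assay, > 1000 nM.
Compound 3, `Cc1cccc(C(=O)NCc2ccc(CNS(=O)(=O)c3ccccc3)cc2)c1`, gives 1000 nM.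

Compound 3 stands at the highest of the two numbers in this assay; its nearest neighbour is compound 1, which sits far lower, beyond the scatter. For the measured compounds named here, the only measured step, an at least 100-fold higher number from compound 1 to compound 2 (2.00 log units; beyond the scatter), concerns a different change, phenyl in place of 2,4,6-trichlorophenyl on a carbonyl carbon, and ends at the limit of > 1000 nM in this assay, at which 1 of the 3 values shown sits, so it speaks to how much the trichlorophenyl contributes rather than to a single methyl. Compound 4, `Cc1ccc(S(=O)(=O)NCc2ccc(CNC(=O)c3cccc(C)c3)cc2)cc1`, differs from compound 3 in one place: methyl in place of hydrogen on an aromatic carbon. Going by the values given here, no measured pair in this set shows a methyl added or removed, so there is no direct guide. With nothing to lean on, the expected outcome is a step within the scatter, no change at the digits printed from compound 3 to compound 4 (within the scatter). Compound 4 is therefore estimated at 1000 nM in this assay, within a range from 300 nM to 3000 nM, and the value may again turn out to be reported only as a limit.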

Compound 4, effective concentration (reported as EC, without a stated level of effect): 1000 nM
Estimate against measurement, compound 4: no gap at the digits printed; measured number inside the range.
By their numbers in this assay, from the lowest: compound 1; then compounds 3 and 4 (each within the scatter of the next).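

In this assay, for the compounds shown here, methyl in place of hydrogen on an aromatic carbon, phenyl to 4-methylphenyl, gives no change at the digits printed from compound 3 to compound 4 (within the scatter), the first direct reading of an added methyl in this set. With that methyl present, 3-methylphenyl in place of 2,4,6-trichlorophenyl on the carbonyl carbon gives a 100-fold higher number from compound 1 to compound 4 (2.00 log units; beyond the scatter), so a single methyl on that ring does not close the large gap left by losing the trichlorophenyl. Methyl in place of hydrogen on an aromatic carbon also gives a number no higher from compound 2 to compound 4 (the limit leaves the size open). The size of that step cannot be read because compound 2 is reported only as a limit: the limit of > 1000 nM in this assay, at which 1 of the 4 values shown sits.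

As far as these compounds go, whether a chlorine, a methoxy or an amine in place of this methyl would move the number stays open. So does the question of which chlorines of the 2,4,6-trichlorophenyl carry the large step.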